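Chloro to fluoro exchange in a three-compound efficacy set

The compounds below may be only part of what the source reports. "The series", "measured", "known", "first", "only" and "open" are said of these compounds alone.

Compound 1 `O=C(O)Cc1sc(C(c2ccccc2)c2ccc(Cl)cc2)nc1-c1ccc(Cl)cc1` is the reference point of the set. In an in vitro functional assay on HEK285-7 cells for antagonist activity at prostaglandin D2 receptor 2 (Homo sapiens), read by BRET and beta-arrestin recruitment (a lower number here means a smaller maximal response, a higher number a larger maximal response), compound 1 gives 80%. Compound 2 `O=C(O)Cc1sc(C(c2ccc(F)cc2)c2ccc(F)cc2)nc1-c1cc(F)nc(F)c1` gives 80% in this assay, and compound 3 `O=C(O)Cc1sc(C(c2ccccc2)c2ccc(O)cc2)nc1-c1ccc(F)cc1` gives 80%. For the measured compounds named here, the three values are level at the digits read and lie within the scatter of the measurement; no order can be drawn among them, and no pair of measured compounds differs in only one place, so no isolated step is available.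

Compound 4 `O=C(O)Cc1sc(C(c2ccccc2)c2ccc(F)cc2)nc1-c1ccc(Cl)cc1` has not yet been measured. Relative to compound 1 the change is fluoro in place of chloro on an aromatic carbon. Going by the values given here, nothing among the measured compounds isolates this single exchange, so the expectation rests on the flat picture: compound 1, compound 2 and compound 3 all reach the same maximal response although they carry different substituents on their aromatic rings. The step from compound 1 to compound 4 is therefore expected to stay within the scatter, no change at the digits printed from compound 1 to compound 4 (within the scatter), with no direction preferred. Compound 4 is estimated to reach 80% in this assay, with a range from 70% to 90%.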

Compound 4, largest response reached (reported as efficacy), in percent of the reference or control that the assay uses: 80%
Beside the measured number, compound 4's estimate shows no gap at the digits printed, and the stated range covers the measured number.
By their numbers in this assay, from the lowest: compounds 1, 2, 3 and 4 (each within the scatter of the next).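

In this assay, the exchange of 4-chlorophenyl for 4-fluorophenyl reads as follows: no change at the digits printed from compound 1 to compound 4 (within the scatter). For the compounds shown here, this is the only step in the set that changes one place alone, so the flat picture no longer rests solely on compounds that differ in several places at once: at this aromatic carbon, para to a large group, one halogen can take the place of the other without a change in maximal response that stands out from the scatter. No independent measurement is available to explain this result.

The compounds shown leave open whether the response at this position would hold with a group other than a halogen, such as an amine or a methoxy group, since all four values lie within the scatter and no compound here marks what would shift the maximal response. Also open, as far as these compounds go, is whether the same exchange would read alike on the other chlorine-bearing ring of compound 4, or whether an amide in place of the carboxylic acid would leave the level intact.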